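The source may report more compounds than this note shows. Statements on the series, on what has been measured and on what is new or still open speak of the compounds shown alone.

Measured so far in an ADME assay on PHF cells (Homo sapiens) for cytotoxicity, read by MTT assay, with a stated time of 24 h; a lower number here means a stronger inhibitor, a higher number a weaker inhibitor:

- compound 1 `CC1=C(SCCC(=O)OC(C[Se]c2ccccc2)C(=O)NCCCCCC(=O)OCc2ccccc2)C(=O)c2ccccc2C1=O`, which in this assay gives 50000 nM
- compound 2 `CC1=C(SCCC(=O)OC(CC[Se]c2ccccc2)C(=O)NCCCCCC(=O)OCc2ccccc2)C(=O)c2ccccc2C1=O`, which in this assay gives 21000 nM
- compound 3 `CC1=C(SCCC(=O)OC(C[Se]c2ccccc2)C(=O)NC(C)(C)C)C(=O)c2ccccc2C1=O`, which in this assay gives 26000 nM

Compound 1 and compound 2 share a core and differ in one place: a group of 8 heavy atoms (7 carbon, 1 selenium; one six-membered aromatic ring of carbon only) in place of a group of 7 heavy atoms (6 carbon, 1 selenium; one six-membered aromatic ring of carbon only), on a saturated chain carbon, two bonds along the chain from a carbonyl carbon and an oxygen next to a carbonyl group. This change gave a 2.4-fold lower number from compound 1 to compound 2 (0.38 log units; beyond the scatter). Compound 3 carries a different amide end than compound 1; the difference between the two cores is not broken down here. Compound 3 sits within the scatter of both compound 2 and compound 1, so no order among these three is claimed beyond the one step above.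

Compound 4 `CC1=C(SCCC(=O)OC(CC[Se]c2ccccc2)C(=O)NC(C)(C)C)C(=O)c2ccccc2C1=O` is not yet measured. It stands to compound 3 as compound 2 stands to compound 1: a group of 8 heavy atoms (7 carbon, 1 selenium; one six-membered aromatic ring of carbon only) in place of a group of 7 heavy atoms (6 carbon, 1 selenium; one six-membered aromatic ring of carbon only), on a saturated chain carbon, two bonds along the chain from a carbonyl carbon and an oxygen next to a carbonyl group. The place of the change is the same word for word in both pairs, so this is the same change made on the core of compound 3.

The expected step is a 2.2-fold lower number from compound 3 to compound 4 (0.34 log units; beyond the scatter), which rests on the single measured occurrence of this change, a 2.4-fold lower number from compound 1 to compound 2 (0.38 log units; beyond the scatter). Among the measured compounds shown here, because a 2.4-fold lower number from compound 1 to compound 2 (0.38 log units; beyond the scatter) is the only example, and because compound 3 gives 26000 nM, the estimate is kept wide enough to include a step no larger than the scatter. Compound 4 is expected to give about 12000 nM in this assay, with a plausible range from 6000 nM to 26000 nM.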

Compound 4, half-maximal inhibitory concentration: 11000 nM
Compound 4: middle estimate off by 1.1-fold (0.04 log units), on the high side; measured number inside the range.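

In this assay, the group of 8 heavy atoms in place of the group of 7 heavy atoms, on the same saturated chain carbon, gives a 2.4-fold lower number from compound 3 to compound 4 (0.37 log units; beyond the scatter). Set beside the earlier pair, the change carries over from the core of compound 1 to the core of compound 3 with no difference in the size of the step: the same change on two cores in this assay, a 2.4-fold lower number (0.38 log units; beyond the scatter) from compound 1 to compound 2 and a 2.4-fold lower number (0.37 log units; beyond the scatter) from compound 3 to compound 4, 1.0-fold (0.00 log units) apart, within the scatter of two such steps. This shows that the step is reproducible across these two cores in this one cytotoxicity read-out, but two pairs do not establish a rule for the series, and they do not show why the added chain carbon lowers the number or whether the step would hold on any other amide end.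

The compounds shown leave open whether the trend continues with a longer chain carrying the selenium and phenyl unit, and whether sulfur in place of selenium gives a step of the same size. They also leave open how the step behaves when a carboxylic acid replaces the benzyl ester at the amide end, or when an amine is carried there, and whether any of these changes moves the number further than the two steps seen so far.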